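Swapping a Fluorinated Aromatic Ring for a Saturated One

This account rests on a few compounds, and the source may have more. Where it says the series, first, only, none or still open, it means among the compounds named here.

Compound 2 `CC(C)c1onc(-c2c(Cl)cccc2Cl)c1COc1ccc(-c2nc3ccc(C(=O)O)cc3n2Cc2ccc(F)cc2)cc1` gives 1140 nM in an assay on HEK-293T cells for antagonist activity at vitamin D3 receptor (Homo sapiens), read by a luciferase reporter, with a stated time of 24 h; on this read-out higher numbers stand for weaker inhibition and lower numbers for stronger inhibition. Among the measured compounds shown here, of the two numbers measured, this is the highest, yet its only neighbour, compound 1 `CC(C)c1onc(-c2c(Cl)cccc2Cl)c1COc1ccc(-c2nc3ccc(C(=O)O)cc3n2C2CCCCCC2)cc1`, gives 921 nM in this assay, and the step of a 1.2-fold higher number from compound 1 to compound 2 (0.09 log units; within the scatter) lies within the scatter, so the two compounds cannot be told apart. Compound 3 `CC(C)c1onc(-c2c(Cl)cccc2Cl)c1COc1ccc(-c2nc3ccc(C(=O)O)cc3n2CC2CCCCC2)cc1` has not yet been measured. It differs from compound 2 by cyclohexyl in place of 4-fluorophenyl on a saturated chain carbon bound to an aromatic nitrogen. For the measured compounds named here, the only measured step that bears on this change is a 1.2-fold higher number from compound 1 to compound 2 (0.09 log units; within the scatter), where a saturated ring on the aromatic nitrogen gave way to a fluorinated aromatic one and nothing beyond the scatter followed. Bringing a saturated ring back in compound 3 is therefore expected to give a step of a 1.1-fold lower number from compound 2 to compound 3 (0.06 log units; within the scatter) that also stays within the scatter. Compound 3 is estimated at 1000 nM, with a range from 450 nM to 2300 nM.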

Compound 3, half-maximal inhibitory concentration: 346 nM
Compound 3: the middle estimate sits 2.9-fold (0.46 log units) above what was measured; measured number outside the range, below it.
By their numbers in this assay, from the lowest: compound 3; then compounds 1 and 2 (each within the scatter of the next).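

In this assay, among the compounds shown here, this position now proves able to move the number: going from 4-fluorobenzyl to cyclohexylmethyl gives a 3.3-fold lower number from compound 2 to compound 3 (0.52 log units; beyond the scatter) and is the first step in this set to pass beyond the scatter. Replacing cycloheptyl on the aromatic nitrogen with cyclohexylmethyl gives a 2.7-fold lower number from compound 1 to compound 3 (0.43 log units; beyond the scatter) as well, so a saturated ring alone does not settle the matter, since compound 1 and compound 3 both carry one and only compound 3, with its ring on a saturated chain carbon, stands apart. No measurement here accounts for these differences.

From the compounds shown here alone, the step from compound 2 removes the fluorine and the aromatic ring together, so which change matters stays open, and a plain benzyl group would separate them. Also open, going by these compounds, is how a longer chain carrying the cyclohexyl ring would read.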